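From a Trienyl Ester to a Monoenyl Ester

The source may hold more compounds than are shown below. What is called first, only, known or untested is meant among the compounds shown, and "the series" means these compounds.

Two esters have been measured so far. Compound 1 `CCCCC/C=C\C/C=C\C/C=C\C/C=C\CCCC(=O)OCC1COC(C)(C)O1` gives 98000 nM in an assay on membranes from cerebellum for inhibition of Fatty-acid amide hydrolase 1 (Rattus norvegicus) (on this read-out higher numbers stand for weaker inhibition and lower numbers for stronger inhibition), while compound 2 `CC/C=C\C/C=C\C/C=C\CCCCCCCC(=O)OCC1CCCCO1` gives 19000 nM in this assay; compound 2 thus has the lower of the two numbers, the stronger inhibition, by a margin beyond the usual scatter. Compound 3 `CCCCCC/C=C\CCCCCCCC(=O)OCC1CCCCO1` has not yet been measured. It differs from compound 2 by pentyl in place of hepta-1,4-dien-1-yl on a saturated chain carbon bound to a double-bonded chain carbon, leaving a shorter, saturated chain end. Among the compounds with values here, with no measured pair showing what this change does, the expected step is a 1.6-fold higher number from compound 2 to compound 3 (0.20 log units; within the scatter), toward weaker inhibition. Compound 3 is therefore expected to give about 30000 nM in this assay, within 8000 nM to 120000 nM.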

Compound 3, half-maximal inhibitory concentration: 10000 nM
Compound 3: the middle estimate sits 3.0-fold (0.48 log units) above what was measured; the range from low to high includes it.
By their numbers in this assay, from the lowest: compounds 3 and 2 (each within the scatter of the next); then compound 1.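

In this assay, within the data shown here, pentyl in place of hepta-1,4-dien-1-yl on a saturated chain carbon bound to a double-bonded chain carbon gives a 1.9-fold lower number from compound 2 to compound 3 (0.28 log units; within the scatter), the first single-place comparison. At this position, then, the chain end can lose both of its double bonds and still give a reading that cannot be told apart from the original. Nothing here explains why the two chain ends read alike. Still open, as far as these compounds go, is whether a longer saturated chain at this position would read the same, and what an amide in place of the ester would do.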